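Swapping 4-Fluorophenyl for 2,4-Dichlorophenyl on the Shared Core

The source may hold more compounds than are shown below. What is called first, only, known or untested is meant among the compounds shown, and "the series" means these compounds.

Of the compounds shown here, three with a shared core have been measured in a functional assay on PC-3 cells (Homo sapiens) for inhibition, read by MTT assay, with a stated time of 72 h; on this read-out lower numbers stand for stronger inhibition and higher numbers for weaker inhibition. Compound 1 `C=CC(=O)Nc1cccc(NC(=O)CSc2nc(Nc3ccccc3Cl)c3ccccc3n2)c1` gives 14400 nM in this assay. Compound 2 `C=CC(=O)Nc1cccc(NC(=O)CSc2nc(Nc3ccccc3Br)c3ccccc3n2)c1` gives 17100 nM in this assay. Compound 3 `C=CC(=O)Nc1cccc(NC(=O)CSc2nc(Nc3ccc(F)cc3)c3ccccc3n2)c1` gives 8240 nM in this assay. Compound 3 stands lowest of the three numbers, though the step of a 1.7-fold lower number from compound 1 to compound 3 (0.24 log units; within the scatter) is within the scatter and only a 2.1-fold lower number from compound 2 to compound 3 (0.32 log units; beyond the scatter) reaches beyond it. Compound 4 `C=CC(=O)Nc1cccc(NC(=O)CSc2nc(Nc3ccc(Cl)cc3Cl)c3ccccc3n2)c1` carries the change (2,4-dichlorophenyl in place of 4-fluorophenyl on a nitrogen on an aromatic ring). The measured steps that bear on this change are the ones that exchange the aryl group on the same nitrogen: a 1.7-fold lower number from compound 1 to compound 3 (0.24 log units; within the scatter) and a 2.1-fold lower number from compound 2 to compound 3 (0.32 log units; beyond the scatter), both moving toward lower numbers when a 4-fluorophenyl takes the place of a 2-chlorophenyl or a 2-bromophenyl. Compound 4 returns to a chlorine-bearing phenyl, now as 2,4-dichlorophenyl, so the expected step in this assay is a modest rise in the number, roughly undoing those steps, a 1.5-fold higher number from compound 3 to compound 4 (0.16 log units; within the scatter). The estimate for compound 4 is therefore 12000 nM, with a range from 5000 nM to 30000 nM.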

Compound 4, half-maximal inhibitory concentration: 25700 nM
The estimate for compound 4 lay 2.1-fold (0.33 log units) below the measured number, within the range that was stated.
By their numbers in this assay, from the lowest: compounds 3, 1, 2 and 4 (each within the scatter of the next, the first and the last beyond it).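

On the nitrogen of the shared core, exchanging 4-fluorophenyl for 2,4-dichlorophenyl gives the largest step seen so far in this assay (a 3.1-fold higher number from compound 3 to compound 4 (0.49 log units; beyond the scatter)), and it lies beyond the usual scatter. Among these compounds, the closer comparisons stay within that scatter: adding a chloro in place of hydrogen on an aromatic carbon gives a 1.8-fold higher number from compound 1 to compound 4 (0.25 log units; within the scatter) and is the only step that changes a single atom on this aryl group, while 2,4-dichlorophenyl in place of 2-bromophenyl gives a 1.5-fold higher number from compound 2 to compound 4 (0.18 log units; within the scatter). Compounds 1, 2 and 4 therefore cannot be told apart, and compound 3 stands clear of compounds 2 and 4 but not of compound 1.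

The compounds shown leave open how 4-chlorophenyl, with its single chloro, or a phenyl carrying a methoxy or an amine would read at this nitrogen. The data offer no measurement that explains these steps.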